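Swapping a bromofuran for a methylphenyl on the acrylamide

This account rests on a few compounds, and the source may have more. Where it says the series, first, only, none or still open, it means among the compounds named here.

Measured so far:
Compound 1, `COc1ccc(CNC(=O)/C(C#N)=C/c2ccc[nH]2)cc1`, gives > 50000 nM in a functional assay on NCI-H460 cells (Homo sapiens) for inhibition, read by MTT assay, with a stated time of 72 h (a higher number here means a weaker inhibitor of growth, a lower number a stronger inhibitor of growth), a limit of the assay.
Compound 2, `COc1ccc(CNC(=O)/C(C#N)=C/c2ccc(Cl)o2)cc1`, gives 15000 nM in this assay.
Compound 3, `COc1ccc(CNC(=O)/C(C#N)=C/c2cc(Br)co2)cc1`, gives > 100000 nM in this assay, again a limit and not a number.

Compound 3 therefore stands at the weak end of what has been seen: its value is the limit noted as the limit of > 100000 nM in this assay, at which 1 of the 3 values shown sits, and no number is known for it. Between compound 2 and compound 3 the change from 5-chlorofuran-2-yl to 4-bromofuran-2-yl gave an at least 6.6-fold higher number from compound 2 to compound 3 (0.82 log units; beyond the scatter). From compound 1 to compound 3 the step is a step that the two limits leave unreadable from compound 1 to compound 3, since compound 1 sits at the limit given as the limit of > 50000 nM in this assay, at which 1 of the 3 values shown sits. From compound 1 to compound 2 there was an at least 3.3-fold lower number from compound 1 to compound 2 (0.52 log units; beyond the scatter).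

Compound 4 is `COc1ccc(CNC(=O)/C(C#N)=C/c2ccc(C)cc2)cc1`. It differs from compound 3 by 4-methylphenyl in place of 4-bromofuran-2-yl on a double-bonded chain carbon bound to a double-bonded chain carbon. For the measured compounds named here, none of the measured steps carries a 4-methylphenyl, so the bearing of the earlier steps is indirect: they show only that the choice of the aryl group moves the numbers modestly in either direction. A step of an at least 2.5-fold lower number from compound 3 to compound 4 (0.39 log units; beyond the scatter) is expected, toward a lower number but with much uncertainty. Compound 4 is estimated at 40000 nM, within 8000 nM to 200000 nM.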

Compound 4, concentration for 50% growth inhibition: 41000 nM
Compound 4: the middle estimate sits 1.0-fold (0.01 log units) below what was measured; measured number inside the range.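

For the compounds shown here, with the 4-methylphenyl group, this place on a double-bonded chain carbon bound to a double-bonded chain carbon carries a six-membered aromatic ring of carbon only for the first time, and this assay returns a measured number where the 4-bromofuran-2-yl group of compound 3 returned only a limit: the limit of > 100000 nM in this assay, at which 1 of the 4 values shown sits. The change gave an at least 2.4-fold lower number from compound 3 to compound 4 (0.38 log units; beyond the scatter), but the same ring does not match the 5-chlorofuran-2-yl group, with a 2.7-fold higher number from compound 2 to compound 4 (0.44 log units; beyond the scatter), so compound 2 remains the strongest of the four. Against the 1H-pyrrol-2-yl group, the change gave an at least 1.2-fold lower number from compound 1 to compound 4 (0.08 log units; that floor lies within the scatter), which fixes no order for that pair.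

The compounds shown leave open whether the lower number of compound 2 goes with the furan ring or with its chlorine, a question that a 5-methylfuran-2-yl or a 4-chlorophenyl group at this place would address. Also open, going by these compounds, is whether an unsubstituted phenyl group would give a number like that of compound 4, and how far the true value of compound 3 lies from it.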